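Working notes: from compound 3 to compound 4

The compounds below may be only part of what the source reports. "The series", "measured", "known", "first", "only" and "open" are said of these compounds alone.

Measured in a functional assay on HT-29 cells (Homo sapiens); a lower number here means a stronger inhibitor of growth, a higher number a weaker inhibitor of growth:
- compound 1 `O=S(=O)(/C=C/c1ccc(Cl)cc1Cl)Cc1ccc(Nc2ncnc3ccccc23)cc1` gives 24000 nM
- compound 2 `O=S(=O)(/C=C/c1ccc(Cl)cc1)Cc1ccc(Nc2ncnc3ccc(Br)cc23)cc1` gives > 100000 nM as a limit
- compound 3 `O=S(=O)(/C=C/c1ccc(O)cc1)Cc1ccc(Nc2ncnc3ccc(Br)cc23)cc1` gives 9000 nM

Among the numbers in this assay compound 3 is the lowest, and compound 1 lies higher. Compound 4 `O=S(=O)(/C=C/c1ccc(Cl)cc1Cl)Cc1ccc(Nc2ncnc3ccc(Br)cc23)cc1` is still unmeasured. It carries 2,4-dichlorophenyl in place of 4-hydroxyphenyl on a double-bonded chain carbon bound to a double-bonded chain carbon. Among the compounds with values here, the one step that bears on this is hydroxy in place of chloro (an at least 11-fold lower number from compound 2 to compound 3 (1.04 log units; beyond the scatter)), which is large, and the present change runs the opposite way. Compound 1 carries the same 2,4-dichlorophenyl and gives 24000 nM on its own core. A large step to a higher number is therefore expected (a 5.6-fold higher number from compound 3 to compound 4 (0.74 log units; beyond the scatter)). For compound 4 the estimate is 50000 nM with an expected range of 15000 nM to 150000 nM in this assay.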

Compound 4, concentration for 50% growth inhibition: 28000 nM
Estimate against measurement, compound 4: 1.8-fold (0.25 log units) above, within the range that was stated.
By their numbers in this assay, from the lowest: compound 3; then compounds 1 and 4 (each within the scatter of the next). At a limit, above all of these: compound 2.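

Measured in this assay the 2,4-dichlorophenyl group on this chain carbon gives a modest loss against 4-hydroxyphenyl (a 3.1-fold higher number from compound 3 to compound 4 (0.49 log units; beyond the scatter)), far from the full loss seen with the 4-chlorophenyl of compound 2. Bromo in place of hydrogen on the core leaves the dichlorinated pair level within the scatter (a 1.2-fold higher number from compound 1 to compound 4 (0.07 log units; within the scatter)). The added chloro gives a gain (an at least 3.5-fold lower number from compound 2 to compound 4 (0.55 log units; beyond the scatter)), but compound 2 stands only at a limit: the limit of > 100000 nM in this assay, at which 1 of the 4 values shown sits.

Open, going by these compounds, is whether methoxy or an amine in place of the 4-hydroxy group holds the lower number. On these data alone, a longer chain between the sulfonyl and the aromatic ring also remains untested here.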